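A few compounds are considered here, and "the series" means these few. Any claim that something is new, unique, unknown or untested is made for them only; others in the source may bear on it.

Working notes on the series, read in a functional assay on SK-OV-3 cells (Homo sapiens) for cytotoxicity (on this read-out lower numbers stand for stronger inhibition and higher numbers for weaker inhibition), throughout. Compound 1 (`C=C/C=C\[C@H](C)[C@H](OC(N)=O)[C@@H](C)[C@H](O)[C@@H](C)C/C(C)=C\[C@H](C)[C@@H](O)[C@@H](C)/C=C\CCc1ccc(C)c(F)c1`) gives 1000 nM there and compound 2 (`C=C/C=C\[C@H](C)[C@H](OC(N)=O)[C@@H](C)[C@H](O)[C@@H](C)C/C(C)=C\[C@H](C)[C@@H](O)[C@@H](C)/C=C\CCc1ccc(C)c(O)c1`) gives 410 nM there, the lower of the two numbers. For the measured compounds named here, the only measured step (a 2.4-fold lower number from compound 1 to compound 2 (0.39 log units; beyond the scatter)) is modest and comes with hydroxy in place of fluoro on an aromatic carbon. Compound 3 (`C=C/C=C\[C@H](C)[C@H](OC(N)=O)[C@@H](C)[C@H](O)[C@@H](C)C/C(C)=C\[C@H](C)[C@@H](O)[C@@H](C)/C=C\CCc1ccsc1`) follows from compound 2 by one change (thiophen-3-yl in place of 3-hydroxy-4-methylphenyl on a saturated chain carbon, two bonds along the chain from a double-bonded chain carbon), thiophen-3-yl in place of 3-hydroxy-4-methylphenyl on a saturated chain carbon. The measured step covers one aromatic carbon only, so it bears on this change only in part. Compound 3 carries no hydroxy, as compound 1 (1000 nM) carries none, so a modest move to a higher number is expected in this assay, with a wide range. The expected step (a 2.2-fold higher number from compound 2 to compound 3 (0.34 log units; beyond the scatter)) is of about the measured size. Compound 3 is estimated at 900 nM with an expected range from 300 nM to 2700 nM on this read-out.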

Compound 3, half-maximal inhibitory concentration: 440 nM
For compound 3 the middle estimate is 2.0-fold (0.31 log units) above the measured one; the range from low to high includes it.
By their numbers in this assay, from the lowest: compounds 2 and 3 (each within the scatter of the next); then compound 1.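

In this assay, the step of a 1.1-fold higher number from compound 2 to compound 3 (0.03 log units; within the scatter) shows that, on a saturated chain carbon, two bonds along the chain from a double-bonded chain carbon, thiophen-3-yl and 3-hydroxy-4-methylphenyl cannot be told apart. The step of a 2.3-fold lower number from compound 1 to compound 3 (0.36 log units; beyond the scatter) shows that a group without hydroxy can still give a lower number than the 3-fluoro-4-methylphenyl of compound 1, so compound 3 goes against reading the step from compound 1 to compound 2 as a hydroxy requirement. No data given here account for either step.

What the compounds shown leave open is whether this result is particular to thiophen-3-yl or also extends to a plain phenyl, thiophen-2-yl or pyridin-3-yl at this place. Also open, on these data alone, is how an amine or a carboxylic acid on the ring would read.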